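The source may hold more compounds than are shown below. What is called first, only, known or untested is meant among the compounds shown, and "the series" means these compounds.

Measured so far:
Compound 1, `O/N=C(\CCN1CCN(c2ccccn2)CC1)c1cccc(Cl)c1`: 73%
Compound 2, `Cc1cccc(/C(CCN2CCN(c3ccccn3)CC2)=N/O)c1`: 74%
Compound 3, `N#Cc1cccc(/C(CCN2CCN(c3ccccn3)CC2)=N/O)c1`: 48%

All three were tested in a functional assay on HEK293 cells with D(4) dopamine receptor (Homo sapiens) as the target, read by FLIPR; on this read-out lower numbers stand for smaller maximal responses and higher numbers for larger maximal responses. Compound 3 stands lowest of the three numbers: the step of a number 25 percentage points lower from compound 1 to compound 3 (beyond the scatter) and the step of a number 26 percentage points lower from compound 2 to compound 3 (beyond the scatter) both lie beyond the scatter, whereas the step of a number 1 percentage points higher from compound 1 to compound 2 (within the scatter) lies within it. In this assay, then, the chloro and methyl compounds 1 and 2 look alike, and compound 3 with its cyano group sits clearly below them.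

Compound 4, `O/N=C(\CCN1CCN(c2ccccn2)CC1)c1ccc(F)cc1F`, has not yet been measured. It differs from compound 3 in one place: 2,4-difluorophenyl in place of 3-cyanophenyl on a carbon with a double bond to nitrogen. The measured steps that bear on this are the two that introduced the cyano group, each lowering the maximal response by about a quarter. Compound 4 removes that cyano group and carries instead a ring with two fluorines, a pattern not present among the measured compounds. The closest guide is that the halogen-bearing compound 1 gives 73%. A return upward toward that level is therefore expected, though with wide uncertainty.

Compound 4 is expected to give about 68%, within 50% to 85%. This estimate means an expected step of a number 20 percentage points higher from compound 3 to compound 4 (beyond the scatter).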

Compound 4, largest response reached (reported as efficacy), in percent of the reference or control that the assay uses: 78%
Compound 4: middle estimate off by 10 percentage points, on the low side, within the range that was stated.
By their numbers in this assay, from the lowest: compound 3; then compounds 1, 2 and 4 (each within the scatter of the next).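

In this assay, putting 2,4-difluorophenyl in place of 3-cyanophenyl on the carbon with a double bond to nitrogen gives a number 30 percentage points higher from compound 3 to compound 4 (beyond the scatter) and so recovers the maximal response lost with the nitrile. The comparisons with the other two compounds, a number 4 percentage points higher from compound 2 to compound 4 (within the scatter) and a number 5 percentage points higher from compound 1 to compound 4 (within the scatter), show that a ring with two fluorines cannot be told apart from the 3-chlorophenyl and 3-methylphenyl rings, so this position accepts quite different ring patterns without a change in this read-out. Among the four compounds, only compound 3 stands apart, and nothing measured here gives a reason for that.

Compound 4 differs from the others in both the kind and the number of ring substituents, so the compounds shown leave open whether a single fluorine would behave the same and whether a nitrile elsewhere on the ring would also lower the response. They also leave open whether the level shared by the other three would hold with a methoxy group, an amine or a carboxylic acid on the ring, or whether any of these would fall as low as the nitrile.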